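The source may hold more compounds than are shown below. What is called first, only, known or untested is meant among the compounds shown, and "the series" means these compounds.

Measured so far:
compound 1 `O=Cc1c(-c2ccc([N+](=O)[O-])cc2)nc2sc(Cc3ccccc3)nn12` — in a functional assay on cells (Melanoma cell, Homo sapiens) for inhibition (on this read-out higher numbers stand for weaker inhibition of growth and lower numbers for stronger inhibition of growth), compound 1 gives 3700 nM
compound 2 `O=[N+]([O-])c1ccc(-c2nc3sc(Cc4ccccc4)nn3c2Br)cc1` — in this assay compound 2 gives 40700 nM

Compound 1 holds the lower of the two numbers in this assay. Within the data shown here, the only measured step is an 11-fold higher number from compound 1 to compound 2 (1.04 log units; beyond the scatter), a change of the group on the core. Compound 3 `O=Cc1c(-c2ccc(Br)cc2)nc2sc(Cc3ccccc3)nn12` is not yet measured; it differs from compound 1 by bromo in place of nitro on an aromatic carbon. Among the measured compounds shown here, that change sits at a different place from the measured step, so no step bears on it directly. A step of moderate size in this assay, most likely towards a higher number, is expected, with wide uncertainty. Compound 3 is expected to give 6000 nM, range 1500 nM to 25000 nM. This estimate means an expected step of a 1.6-fold higher number from compound 1 to compound 3 (0.21 log units; within the scatter).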

Compound 3, concentration for 50% growth inhibition: 3200 nM
For compound 3 the middle estimate is 1.9-fold (0.27 log units) above the measured one; the measured number falls inside the stated range.
By their numbers in this assay, from the lowest: compounds 3 and 1 (each within the scatter of the next); then compound 2.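

In this assay, bromo replaces nitro on the six-membered aromatic ring of carbon only, para to a large group, with a 1.2-fold lower number from compound 1 to compound 3 (0.06 log units; within the scatter). Among these compounds, at this place, then, the number does not depend on keeping the nitro group, unlike the change on the core, where the only earlier step was beyond the scatter. No measurement on hand gives a reason for this result.

Still open, on these data alone, is whether an amine or a carboxylic acid at this place would leave the number unchanged. Also open, as far as these compounds go, is whether a longer chain would do so.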